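This account rests on a few compounds, and the source may have more. Where it says the series, first, only, none or still open, it means among the compounds named here.

Compound 1 `COc1ccc(Nc2nc3ccccc3nc2S(=O)(=O)c2ccc(C)cc2)cc1` and compound 2 `Cc1ccc(S(=O)(=O)c2nc3ccccc3nc2Nc2cccc(O)c2)cc1` share the same core and differ only in the aryl group carried on the ring nitrogen. In a functional assay on A549 cells (Homo sapiens) for cytotoxicity, read by MTT assay, with a stated time of 72 h (on this read-out lower numbers stand for stronger inhibition and higher numbers for weaker inhibition), compound 1 gives > 50000 nM, which is a limit of the assay rather than a number. In this assay compound 2 gives 6080 nM. Among the compounds with values here, the step of an at least 8.2-fold lower number from compound 1 to compound 2 (0.91 log units; beyond the scatter) shows the only measured change, and it lies on the nitrogen-bound aryl group, not on the sulfonyl aryl group. Compound 3 `COc1ccc(Nc2nc3ccccc3nc2S(=O)(=O)c2ccc(F)cc2)cc1` is not yet measured. It differs from compound 1 by fluoro in place of methyl on an aromatic carbon, that is, on an aromatic carbon of a six-membered aromatic ring of carbon only, para to a large group. Within the data shown here, no measured step touches this part of the structure, so the evidence available gives no direction for the change. Compound 1 sits at the limit (the limit of > 50000 nM in this assay, at which 1 of the 2 values shown sits), and a swap of methyl for fluoro is a small change in size. Compound 3 is therefore expected to stay near that limit, and the step of a number no higher from compound 1 to compound 3 (the limit leaves the size open) is estimated as none beyond the scatter. The value for compound 3 in this assay is estimated at 50000 nM, within 15000 nM to 150000 nM.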

Compound 3, half-maximal inhibitory concentration: 4840 nM
Beside the measured number, compound 3's estimate is 10-fold (1.01 log units) above it, outside the stated range (below it).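

Within the data shown here, the aryl group on the sulfonyl, which no earlier step had touched, proves to be far from a silent part of the structure: fluoro in place of methyl on an aromatic carbon, para to a large group, brings an at least 10-fold lower number from compound 1 to compound 3 (1.01 log units; beyond the scatter) in this assay with the exchange of one heavy atom for one heavy atom. The shared core therefore responds at two places, since one single change on the nitrogen-bound aryl group and one on the sulfonyl aryl group each lead away from compound 1 by a step beyond the scatter. On these data alone, compound 1 gives > 50000 nM, which is a limit of the assay and not a number, so the true size of the step stays open.

What the compounds shown leave open is whether this gain belongs to fluoro itself or would also come with chloro, a nitrile, an amine or plain hydrogen at the same position. They also leave open whether 4-fluorophenyl on the sulfonyl would act in the same way alongside the 3-hydroxyphenyl group of compound 2.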